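Fluoro on the benzamide ring: cytotoxicity of compound 3

A few compounds are considered here, and "the series" means these few. Any claim that something is new, unique, unknown or untested is made for them only; others in the source may bear on it.

compound 1 `O=C(NC/C=C\Cn1ccc(=O)[nH]c1=O)c1ccccc1`: > 100000 nM
compound 2 `O=C(NC/C=C\Cn1cc(C(F)(F)F)c(=O)[nH]c1=O)c1ccccc1`: > 100000 nM

Among the compounds with values here, compound 1, `O=C(NC/C=C\Cn1ccc(=O)[nH]c1=O)c1ccccc1`, and compound 2, `O=C(NC/C=C\Cn1cc(C(F)(F)F)c(=O)[nH]c1=O)c1ccccc1`, are the two measured members. In a functional assay on HEp-2 cells (Homo sapiens) for cytotoxicity, read by MTT assay, with a stated time of 72 h (on this read-out lower numbers stand for stronger inhibition and higher numbers for weaker inhibition), compound 1 gives only a limit, > 100000 nM. Compound 2 likewise gives only a limit in this assay, > 100000 nM. The step between them, a step that the two limits leave unreadable from compound 1 to compound 2, cannot be read in size; both values sit at the limit of > 100000 nM in this assay, at which 2 of the 2 values shown sit. Within the data shown here, compound 1 thus stands on no number at all, only a limit, and the one further value shown is also a limit.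

Compound 3, `O=C(NC/C=C\Cn1ccc(=O)[nH]c1=O)c1ccc(F)cc1`, differs from compound 1 as follows: fluoro in place of hydrogen on an aromatic carbon. Among the measured compounds shown here, no measured step touches this ring; the only measured step, a step that the two limits leave unreadable from compound 1 to compound 2, concerns the other ring and is itself unreadable. Nothing in hand supports a step beyond the scatter, and the expectation is that compound 3 again reaches only the assay limit. Compound 3 is therefore estimated at 150000 nM, range 50000 nM to 500000 nM, meaning an expected step that the limit leaves unreadable from compound 1 to compound 3.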

Compound 3, half-maximal inhibitory concentration: > 100000 nM
Compound 3: a limit, no number; the forecaster's own chance of this, stated with the estimate: 85%; the middle value does not contradict the limit.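

The step from compound 1 to compound 3 cannot be read in this assay, because both values are limits and not numbers: the limit of > 100000 nM in this assay, at which 3 of the 3 values shown sit.

The compounds shown leave open whether fluoro or trifluoromethyl changes cytotoxicity at all, as none of them gives a number in this assay.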